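Oxygen to Sulfur on the Alkoxy Chain of Compound 3

This account rests on a few compounds, and the source may have more. Where it says the series, first, only, none or still open, it means among the compounds named here.

Measured compounds:
compound 1 `COc1nccnc1C1CN2CCC1CC2` 1%
compound 2 `CCCCCOc1nccnc1C1CN2CCC1CC2` 32%
compound 3 `CCCCCCOc1nccnc1C1CN2CCC1CC2` 40%

In a functional assay on A9L-m1 cells with A9 (Mus musculus) as the target (on this read-out higher numbers stand for larger maximal responses and lower numbers for smaller maximal responses), compound 3 gives the highest of the three numbers, though its value and that of compound 2 lie within the scatter of each other, so neither can be called the larger. Compound 4 `CCCCSc1nccnc1C1CN2CCC1CC2` differs from compound 3 by butylsulfanyl in place of hexyloxy on an aromatic carbon: a group of five heavy atoms replaces one of seven, and sulfur replaces oxygen. The measured steps bear on chain length only: a number 31 percentage points higher from compound 1 to compound 2 (beyond the scatter) and a number 39 percentage points higher from compound 1 to compound 3 (beyond the scatter) were large, while a number 8 percentage points higher from compound 2 to compound 3 (within the scatter) was not. A butyl chain on the ring is thus expected to sit near compound 2 and compound 3; the oxygen-to-sulfur swap is uncovered by any step. Compound 4 is therefore estimated at 32% in this assay, between 12% and 50%, a step of a number 8 percentage points lower from compound 3 to compound 4 (within the scatter) that is expected to stay within the scatter.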

Compound 4, largest response reached (reported as maximum), in percent of the reference or control that the assay uses: 5%
Estimate against measurement, compound 4: 27 percentage points above; the whole stated range lies above it.
By their numbers in this assay, from the lowest: compounds 1 and 4 (each within the scatter of the next); then compounds 2 and 3 (each within the scatter of the next).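

In this assay the butylsulfanyl group on this aromatic carbon does not keep the response seen with the longer alkoxy chains, with a number 35 percentage points lower from compound 3 to compound 4 (beyond the scatter) and a number 27 percentage points lower from compound 2 to compound 4 (beyond the scatter) in the same assay. The same group stays level with methoxy, with a number 4 percentage points higher from compound 1 to compound 4 (within the scatter) there, so a chain at this position does not by itself bring the response. No evidence is available on why the response is lost here.

The compounds shown leave open whether the sulfur or the shorter chain matters. Butoxy and hexylsulfanyl on this carbon would separate those two changes.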